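Swapping chloro for dimethylamino on the anilide ring

A few compounds are considered here, and "the series" means these few. Any claim that something is new, unique, unknown or untested is made for them only; others in the source may bear on it.

Measured in a functional assay on HT-29 cells (Homo sapiens) for antiproliferative activity, with a stated time of 48 h; a higher number here means that more compound is needed for the effect, a lower number that less compound is needed:
- compound 1 `O=C(CCCCCCC(=O)Nc1cccc(C(F)(F)F)c1)NO` gives 6400 nM
- compound 2 `O=C(CCCCCCC(=O)Nc1ccc(C(F)(F)F)cc1)NO` gives 1400 nM
- compound 3 `O=C(CCCCCCC(=O)Nc1ccc(Cl)cc1)NO` gives 2100 nM

Compound 3 and compound 2 lie within the scatter of each other, while compound 1 shows a clearly higher number than both. The next compound to be tested is compound 4 `CN(C)c1ccc(NC(=O)CCCCCCC(=O)NO)cc1`, and the change from compound 3 is dimethylamino in place of chloro on an aromatic carbon in which dimethylamino takes the place of chloro on an aromatic carbon, para to a large group.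

Among the compounds with values here, one measured step bears on this, the exchange of trifluoromethyl for chloro on an aromatic carbon, a 1.5-fold higher number from compound 2 to compound 3 (0.18 log units; within the scatter) and it stays within the scatter. Within the data shown here, it is only a weak guide, since no compound here carries dimethylamino. No step beyond the scatter is therefore expected in this assay, though the range must stay wide and a shift in either direction remains possible.

The expected step is a 1.2-fold higher number from compound 3 to compound 4 (0.08 log units; within the scatter) as a rough estimate. For compound 4 the estimated value is 2500 nM with an expected range from 900 nM to 7000 nM as the likely span.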

Compound 4, half-maximal effective concentration: 3150 nM
The estimate for compound 4 lay 1.3-fold (0.10 log units) below the measured number; the measured number falls inside the stated range.
By their numbers in this assay, from the lowest: compounds 2, 3 and 4 (each within the scatter of the next, the first and the last beyond it); then compound 1.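

In this assay the replacement of chloro by dimethylamino, para to a large group, gives a 1.5-fold higher number from compound 3 to compound 4 (0.18 log units; within the scatter), so these two groups cannot be told apart here even though dimethylamino carries more heavy atoms. Set against trifluoromethyl at the same place, dimethylamino gives a 2.3-fold higher number from compound 2 to compound 4 (0.35 log units; beyond the scatter), a modest step and the first at this place to pass the scatter, so compounds 2, 3 and 4 fill a narrow band whose two ends can only just be separated. No measurement is available to explain these small differences.

On these data alone, whether a plain amine or a carboxylic acid at this place would stay within the same band remains open. Also open, as far as these compounds go, is how dimethylamino would fare at the ring place where compound 1 carries its trifluoromethyl.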